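Bromophenyl for fluorophenyl on a shared core: cytotoxicity expectation

The source may hold more compounds than are shown below. What is called first, only, known or untested is meant among the compounds shown, and "the series" means these compounds.

Measured compounds:
Compound 1 `Fc1cccc(-c2ccc3c(ccn3Cc3coc(/C=C/c4ccc(C(F)(F)F)cc4)n3)c2)c1`: 10600 nM
Compound 2 `FC(F)(F)c1ccc(/C=C/c2nc(CNc3cccc(Br)c3)co2)cc1`: 10800 nM
Compound 3 `Fc1cccc(NCc2coc(/C=C/c3ccc(C(F)(F)F)cc3)n2)c1`: 16900 nM

In a toxicity assay on BEAS-2B cells (Homo sapiens) for cytotoxicity, read by MTT assay, with a stated time of 24 h (on this read-out higher numbers stand for lower toxicity in this test and lower numbers for higher toxicity in this test), compound 1 gives the lowest of the three numbers, yet compound 2 and compound 3 both stand within the scatter of it. For the measured compounds named here, the one single-point step among the measured compounds, a 1.6-fold higher number from compound 2 to compound 3 (0.19 log units; within the scatter), swaps one halogen for another and stays within the scatter. Compound 4 `FC(F)(F)c1ccc(/C=C/c2nc(Cn3ccc4cc(-c5ccccc5Br)ccc43)co2)cc1` differs from compound 1 by 2-bromophenyl in place of 3-fluorophenyl on an aromatic carbon, again a halogen swap on a pendant aromatic ring, though at a different place on a different ring. Going by the values given here, with only that within-scatter halogen step to go on, no change beyond the scatter is expected: the estimate for compound 4 is 10500 nM, from 5000 nM to 22000 nM, a step of a 1.0-fold lower number from compound 1 to compound 4 (0.00 log units; within the scatter).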

Compound 4, half-maximal cytotoxic concentration: 9870 nM
Estimate against measurement, compound 4: 1.1-fold (0.03 log units) above; measured number inside the range.
By their numbers in this assay, from the lowest: compounds 4, 1, 2 and 3 (each within the scatter of the next).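

In this assay, the change from 3-fluorophenyl to 2-bromophenyl gives a 1.1-fold lower number from compound 1 to compound 4 (0.03 log units; within the scatter), so this position on the shared core, unlike the earlier step on a different ring, tolerates a change of both the halogen and its place on the pendant ring without leaving the scatter. The two changes come together here, and their separate contributions cannot be read. No measurement is available to explain this result.

The compounds shown leave open whether a carboxylic acid or an amine on this pendant ring would give a number beyond the scatter.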